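Removing One Methyl from a Potent Compound

The compounds below may be only part of what the source reports. "The series", "measured", "known", "first", "only" and "open" are said of these compounds alone.

Measured in a functional assay on HeLa cells (Homo sapiens) for cytotoxicity, read by sulforhodamine B assay; on this read-out lower numbers stand for stronger inhibition and higher numbers for weaker inhibition:
- Compound 1 `COc1ccc2c(c1)CCCN2c1nc(C)nc2ccccc12`: 1.2 nM
- Compound 2 `CSc1ccc(N(C)c2nc(C)nc3ccccc23)cc1`: 1.3 nM

Compound 1 and compound 2 lie within the usual scatter of each other, so neither ranks above the other, and both numbers are low. Compound 3 `COc1ccc2c(c1)CCCN2c1ncnc2ccccc12` keeps the core of compound 1 with one change: hydrogen in place of methyl on an aromatic carbon. Among the compounds with values here, no measured pair shows this change, so any forecast is uncertain. A moderate weakening in this assay, beyond the scatter, is expected. The estimated shift is a 5.0-fold higher number from compound 1 to compound 3 (0.70 log units; beyond the scatter). For compound 3, the estimated value is 6 nM, within a range of 1.5 nM to 30 nM.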

Compound 3, half-maximal inhibitory concentration: 16.8 nM
For compound 3 the middle estimate is 2.8-fold (0.45 log units) below the measured one; low and high end bracket the measured number.
By their numbers in this assay, from the lowest: compounds 1 and 2 (each within the scatter of the next); then compound 3.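

In this assay, hydrogen in place of methyl on this aromatic carbon gives a 14-fold higher number from compound 1 to compound 3 (1.15 log units; beyond the scatter), so a single carbon at this position makes a large difference. Activity is reduced but not lost, as compound 3 still gives 16.8 nM in this low range. Nothing available explains why this methyl matters so much.

From the compounds shown here alone, whether an ethyl group or an amine on the same carbon would match the methyl remains open. So does whether removing the same methyl from compound 2 would cost as much.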